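Swapping a hydroxybutenyl chain for a methyl enoate

The source may report more compounds than this note shows. Statements on the series, on what has been measured and on what is new or still open speak of the compounds shown alone.

Four compounds share a six-membered oxygen-containing ring. Compound 1 `COC(=O)/C=C/C[C@H]1OCCC[C@@H]1OC(=O)c1ccccc1` carries a benzoate and a methyl ester chain; in a functional assay on MCF7S cells (Homo sapiens) (a lower number here means a stronger inhibitor of growth, a higher number a weaker inhibitor of growth), compound 1 gives "not active" (no number reported), with no number given. For the measured compounds named here, compound 2 `CC(C)(C)[Si](C)(C)O[C@H]1CCCO[C@@H]1C/C=C/CO` bears a silyl ether on the ring and a 4-hydroxybut-2-en-1-yl chain, and in this assay compound 2 gives 25000 nM, the lowest of the two numbers known. Compound 3 `CC(C)(C)[Si](C)(C)OC/C=C/[C@H]1OCCC[C@@H]1O` places the silyl ether on the chain and leaves the ring hydroxyl free; in this assay compound 3 gives 86000 nM, a step beyond the usual scatter from compound 2.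

Compound 4 `COC(=O)/C=C\[C@H]1OCCC[C@@H]1O[Si](C)(C)C(C)(C)C` has not been measured. It differs from compound 2 in one place: 2-(methoxycarbonyl)ethenyl in place of 4-hydroxybut-2-en-1-yl on a saturated ring carbon. Going by the values given here, with compound 1 inactive, the only measured compound carrying a methoxycarbonyl group, a modest step toward a weaker number is expected, a 2.0-fold higher number from compound 2 to compound 4 (0.30 log units; within the scatter). For compound 4 an estimate of 50000 nM, within 12000 nM to 200000 nM, is expected in this assay.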

Compound 4, concentration for 50% growth inhibition: 32000 nM
Beside the measured number, compound 4's estimate is 1.6-fold (0.19 log units) above it, and the stated range covers the measured number.
By their numbers in this assay, from the lowest: compounds 2 and 4 (each within the scatter of the next); then compound 3.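

The swap of 4-hydroxybut-2-en-1-yl for 2-(methoxycarbonyl)ethenyl on this saturated ring carbon, next to the ring oxygen, gives in this assay a 1.3-fold higher number from compound 2 to compound 4 (0.11 log units; within the scatter), so the two compounds cannot be told apart. The entering group has 0 hydrogen-bond donors and the leaving group has 1, yet with the silyl ether held in place, this position accepts the change without a step beyond the scatter. Nothing measured on this pair speaks to the reason for that.

One pair cannot show whether this tolerance extends to other chains at this position, such as one ending in a carboxylic acid or an amine, or a longer saturated carbon chain. It also leaves open whether the same swap would give so small a step with a group other than the silyl ether on the neighbouring ring atom.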